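A few compounds are considered here, and "the series" means these few. Any claim that something is new, unique, unknown or untested is made for them only; others in the source may bear on it.

Compound 2 `O=C(NCCCCc1ccccc1)c1cccc(C2SCC(=O)N2c2ccccc2)c1`: 68%
Compound 3 `O=C(NCCCCc1ccccc1)c1cccc(C2SCC(=O)N2c2cccc(F)c2)c1`: 39%
Compound 1 `COc1ccc(F)cc1N1C(=O)CSC1c1cccc(C(=O)NCCCCc2ccccc2)c1`: 32%

In a functional assay on U2OS cells (Homo sapiens) for inhibition, read by CCK-8 assay, with a stated time of 72 h, tested at 1 uM (a lower number here means less inhibition, a higher number more inhibition at the concentration tested (going by the name of the read-out)), compound 2 stands highest of the three numbers, both others beyond the scatter below it. Compound 4 `COc1c(F)cccc1N1C(=O)CSC1c1cccc(C(=O)NCCCCc2ccccc2)c1` differs from compound 2 by 3-fluoro-2-methoxyphenyl in place of phenyl on an amide-type nitrogen in a ring. Among the measured compounds shown here, two measured steps bear on this change. Putting phenyl in place of 5-fluoro-2-methoxyphenyl moved the read-out a number 36 percentage points higher from compound 1 to compound 2 (beyond the scatter), and putting fluoro in place of hydrogen moved it a number 29 percentage points lower from compound 2 to compound 3 (beyond the scatter). Each decorated phenyl on the amide-type nitrogen in the ring sat lower than the bare phenyl, while a number 7 percentage points higher from compound 1 to compound 3 (within the scatter) shows that hydrogen in place of methoxy alone changed little. A drop beyond the scatter is therefore expected, a number 32 percentage points lower from compound 2 to compound 4 (beyond the scatter). Compound 4 is estimated at 36%, within 16% to 56%.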

Compound 4, a percentage reported as inhibition, at one concentration (the size of the read-out at that concentration, not a potency): 12%
For compound 4 the middle estimate is 24 percentage points above the measured one; measured number outside the range, below it.
By their numbers in this assay, from the lowest: compound 4; then compounds 1 and 3 (each within the scatter of the next); then compound 2.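

In this assay, the 3-fluoro-2-methoxyphenyl group on the amide-type nitrogen removes most of the read-out of the bare phenyl (a number 56 percentage points lower from compound 2 to compound 4 (beyond the scatter)). The placing of methoxy relative to fluoro matters: methoxy counts for little in one arrangement (a number 7 percentage points higher from compound 1 to compound 3 (within the scatter)) but for much in the other (a number 27 percentage points lower from compound 3 to compound 4 (beyond the scatter)), and the two fluoro-methoxy arrangements are themselves separated (a number 20 percentage points lower from compound 1 to compound 4 (beyond the scatter)). No evidence on the cause of these steps is available.

Open, going by these compounds, is how 2-methoxyphenyl without fluoro would read. Also open, on these data alone, is whether an amine or a carboxylic acid on this phenyl would keep the read-out of compound 2.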